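The source may hold more compounds than are shown below. What is called first, only, known or untested is meant among the compounds shown, and "the series" means these compounds.

Measured so far:
- compound 1 `COc1cc(C(=O)NC2CCN(C)CC2)ccc1Nc1ncc(Br)c(NC2CCCC2)n1`: 3500 nM
- compound 2 `COc1cc(C(=O)NC2CCN(C)CC2)ccc1Nc1ncc(Cl)c(NC2CCCC2)n1`: 2700 nM
- compound 3 `CN1CCC(NC(=O)c2ccc(Nc3ncc(F)c(NC4CCCC4)n3)cc2)CC1`: 45500 nM

These three compounds were tested in a functional assay on HeLa cells (Homo sapiens) for cytotoxicity, read by MTT assay, with a stated time of 48 h; on this read-out lower numbers stand for stronger inhibition and higher numbers for weaker inhibition. Compound 3 gives the highest number of the three, and its value stands well apart from those of compound 1 and compound 2, which lie close to each other. Within the data shown here, the one measured step between neighbours is a 1.3-fold lower number from compound 1 to compound 2 (0.11 log units; within the scatter), a halogen swap that left the number essentially unchanged.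

Compound 4 `COc1cc(C(=O)NC2CCN(C)CC2)ccc1Nc1ncc(F)c(NC2CCCC2)n1` is the next step from compound 3. Its change is methoxy in place of hydrogen on an aromatic carbon. Among the measured compounds shown here, no measured step alters this position directly, so the halogen step gives no guide to it. What the numbers do show is that compound 1 and compound 2, which both carry the methoxy group, sit far below compound 3, which lacks it, while their own halogen differences matter little. On that basis compound 4 is expected to fall near compound 1 and compound 2, a step of a 13-fold lower number from compound 3 to compound 4 (1.11 log units; beyond the scatter), with the estimate for compound 4 at 3500 nM and a range from 1500 nM to 10000 nM.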

Compound 4, half-maximal inhibitory concentration: 2200 nM
Compound 4: middle estimate off by 1.6-fold (0.20 log units), on the high side; low and high end bracket the measured number.
By their numbers in this assay, from the lowest: compounds 4, 2 and 1 (each within the scatter of the next); then compound 3.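

Compound 3 and compound 4 differ only in methoxy in place of hydrogen, so this pair isolates that change on an aromatic carbon, ortho to a large group. In this assay, among these compounds, it gives a 21-fold lower number from compound 3 to compound 4 (1.32 log units; beyond the scatter), a large step that no earlier pair could show directly. With the methoxy group in place, swapping the halogen makes no readable difference: fluoro in place of chloro gives a 1.2-fold lower number from compound 2 to compound 4 (0.09 log units; within the scatter), and fluoro in place of bromo gives a 1.6-fold lower number from compound 1 to compound 4 (0.20 log units; within the scatter), both within the scatter.

From the compounds shown here alone, whether this step needs methoxy itself stays open, since a hydroxy, ethoxy or chloro group on the same carbon could give a different number. Nothing available explains why the methoxy group has so large an effect here.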